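From Hydroxy to Fluoro in a Growth Inhibitor Series

This account rests on a few compounds, and the source may have more. Where it says the series, first, only, none or still open, it means among the compounds named here.

Compounds in a functional assay on SK-MEL-5 cells (Homo sapiens) for inhibition; a lower number here means a stronger inhibitor of growth, a higher number a weaker inhibitor of growth:

Compound 1 `COc1ccc(-n2cnnc2-c2cc(OC)c(OC)c(OC)c2)cc1`: 2400 nM
Compound 2 `COc1ccc(-n2cnnc2-c2cc(OC)c(OC)c(OC)c2)cc1O`: 288 nM
Compound 3 `COc1ccc(-n2cnnc2-c2cc(OC)c(OC)c(OC)c2)cc1F`: not yet measured

Of the two measured compounds, compound 2 has the lower number, at 288 nM. Compound 3 differs from it by one change: fluoro in place of hydroxy on an aromatic carbon. This places fluoro in place of hydroxy on an aromatic carbon, ortho to a methoxy group and meta to a large group.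

Among the measured compounds shown here, only one measured step bears on this change. Hydroxy in place of hydrogen on an aromatic carbon gave an 8.3-fold lower number from compound 1 to compound 2 (0.92 log units; beyond the scatter), a modest step beyond the scatter. For the measured compounds named here, no measured compound carries fluoro, so the data offer no direct guide to it. Compound 3 also lacks the hydroxy present in compound 2, so a move towards the value of compound 1 seems more likely than a further fall in this assay. The expected change is a 2.4-fold higher number from compound 2 to compound 3 (0.39 log units; beyond the scatter), smaller than the measured step but uncertain in size. The estimated value for compound 3 is 700 nM, with an expected range of 150 nM to 3000 nM.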

Compound 3, concentration for 50% growth inhibition: 2570 nM
The estimate for compound 3 lay 3.7-fold (0.56 log units) below the measured number; low and high end bracket the measured number.
By their numbers in this assay, from the lowest: compound 2; then compounds 1 and 3 (each within the scatter of the next).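

In this assay, fluoro in place of hydroxy gave an 8.9-fold higher number from compound 2 to compound 3 (0.95 log units; beyond the scatter), while fluoro in place of hydrogen gave a 1.1-fold higher number from compound 1 to compound 3 (0.03 log units; within the scatter). Fluoro on this aromatic carbon, ortho to a methoxy group and meta to a large group, therefore does not carry the gain seen with hydroxy in an 8.3-fold lower number from compound 1 to compound 2 (0.92 log units; beyond the scatter), and the earlier pair alone could not separate a gain specific to hydroxy from one shared with another small group. Among the three compounds, the lower number goes with hydroxy, the one entering or leaving group here counted with a hydrogen-bond donor and acceptor, but nothing measured here explains why the two groups differ.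

The compounds shown leave open whether that count is what matters, since an amine or a hydroxymethyl group on the same carbon would test whether another group with a donor can also hold the lower number. They also leave open whether the hydroxy gain would persist with a chloro group on a neighbouring part of the shared core, or with the methoxy groups of that core replaced by ethoxy groups.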